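Phenyl swaps on the carbonyl carbon: toward compound 4

The compounds below may be only part of what the source reports. "The series", "measured", "known", "first", "only" and "open" are said of these compounds alone.

- compound 1 `COc1cc(C2Oc3cc([C@H]4Oc5cc(O)cc(O)c5C(=O)[C@@H]4O)ccc3OC2COC(=O)c2ccc(N)cc2)ccc1O` gives 14300 nM
- compound 2 `COc1cc(C2Oc3cc([C@H]4Oc5cc(O)cc(O)c5C(=O)[C@@H]4O)ccc3OC2COC(=O)c2ccccc2)ccc1O` gives 12700 nM
- compound 3 `COc1cc(C2Oc3cc([C@H]4Oc5cc(O)cc(O)c5C(=O)[C@@H]4O)ccc3OC2COC(=O)c2cccc(Cl)c2)ccc1O` gives 14200 nM

In a functional assay on liver (Rattus norvegicus, strain Sprague-Dawley) for inhibition, with a stated time of 1 h (on this read-out lower numbers stand for stronger inhibition and higher numbers for weaker inhibition), compound 3 cannot be separated from the other two compounds: a 1.0-fold lower number from compound 1 to compound 3 (0.00 log units; within the scatter) and a 1.1-fold higher number from compound 2 to compound 3 (0.05 log units; within the scatter) both lie within the scatter. The next change leads to compound 4 `COc1cc(C2Oc3cc([C@H]4Oc5cc(O)cc(O)c5C(=O)[C@@H]4O)ccc3OC2COC(=O)c2cc([N+](=O)[O-])cc([N+](=O)[O-])c2)ccc1O` and is 3,5-dinitrophenyl in place of 3-chlorophenyl on a carbonyl carbon, with 3,5-dinitrophenyl in place of 3-chlorophenyl on a carbonyl carbon. All three measured steps alter the same phenyl group. Besides the two already given, a 1.1-fold lower number from compound 1 to compound 2 (0.05 log units; within the scatter) also stays within the scatter. None of these steps introduces a nitro group, so they guide the expectation only loosely. On this evidence, no step beyond the scatter is expected in this assay, and no direction can be favoured with confidence. The expected change is a 1.2-fold lower number from compound 3 to compound 4 (0.07 log units; within the scatter). For compound 4 the estimate is 12000 nM, with an expected range from 6000 nM to 23000 nM.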

Compound 4, half-maximal inhibitory concentration: 14600 nM
Beside the measured number, compound 4's estimate is 1.2-fold (0.09 log units) below it; the range from low to high includes it.
By their numbers in this assay, from the lowest: compounds 2, 3, 1 and 4 (each within the scatter of the next).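

In this assay, going by these compounds alone, 3,5-dinitrophenyl on the carbonyl carbon is the first group with nitro groups and with hydrogen-bond acceptors, yet the number stays within the scatter of all three earlier compounds: a 1.0-fold higher number from compound 3 to compound 4 (0.01 log units; within the scatter) and a 1.1-fold higher number from compound 2 to compound 4 (0.06 log units; within the scatter) and also a 1.0-fold higher number from compound 1 to compound 4 (0.01 log units; within the scatter) in the same way. Across the four compounds, then, swapping one substituted phenyl for another at this position has not moved the number beyond the scatter, and compound 4 extends this to the largest group shown so far. No evidence is available that would explain this flat result.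

Still open, as far as these compounds go, is whether a group other than a substituted phenyl, such as a longer alkyl chain or a saturated ring, would behave the same way on this carbonyl carbon. A carboxylic acid on the phenyl ring is equally untested in the compounds shown.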